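The source may report more compounds than this note shows. Statements on the series, on what has been measured and on what is new or still open speak of the compounds shown alone.

Compound 1 `O=C(Nc1ccc(Cl)c(-c2nnc3c(Cl)cccn23)c1)c1ccc(F)cc1Cl` in a functional assay on HeLa cells (Homo sapiens) for antiproliferative activity, read by MTT assay, with a stated time of 72 h (on this read-out higher numbers stand for weaker inhibition and lower numbers for stronger inhibition), gives > 100000 nM, which is a limit of the assay rather than a number.
Compound 2 `O=C(Nc1ccc(Cl)c(-c2nnc3c(Cl)cccn23)c1)c1cccnc1` in this assay gives > 100000 nM, again a limit.
Compound 3 `O=C(Nc1ccc(Cl)c(-c2nnc3c(Cl)cccn23)c1)c1cccc(Cl)c1` in this assay gives > 100000 nM, also a limit.

Compound 3 therefore stands at the same point as every other value shown, namely (the limit of > 100000 nM in this assay, at which 3 of the 3 values shown sit). Compound 4 `Cc1cc(Cl)ccc1C(=O)Nc1ccc(Cl)c(-c2nnc3c(Cl)cccn23)c1` differs from compound 3 in one place: 4-chloro-2-methylphenyl in place of 3-chlorophenyl on a carbonyl carbon. Among the measured compounds shown here, three measured steps touch the same position on the carbonyl carbon, yet none of them gives a readable size, since all three values are limits: a step that the two limits leave unreadable from compound 1 to compound 3, a step that the two limits leave unreadable from compound 2 to compound 3 and a step that the two limits leave unreadable from compound 1 to compound 2. The shown data thus offer no measured step on which a direction or size for the change to compound 4 could rest. The expected step from compound 3 to compound 4 is accordingly a step that the limit leaves unreadable from compound 3 to compound 4, which means no movement beyond the scatter that can be supported. Compound 4 is expected to give 150000 nM, within the range 40000 nM to 600000 nM, and most probably this assay will again report only a limit for it.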

Compound 4, half-maximal inhibitory concentration: > 100000 nM
Compound 4: a limit, no number; the forecaster's own chance of this, stated with the estimate: 85%; the middle value is on the limit's open side.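

Compound 4 also gives a limit rather than a number, so its steps from compound 1, compound 2 and compound 3 cannot be read: the limit of > 100000 nM in this assay, at which 4 of the 4 values shown sit.

The compounds shown leave open whether any group on the carbonyl carbon would give a readable number rather than a limit.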